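The source may hold more compounds than are shown below. What is called first, only, known or untested is meant among the compounds shown, and "the series" means these compounds.

Measured compounds:

Compound 1 `O=C1N(CCCCCCOc2ccc(Cl)cc2)CCN1c1ccncc1` — in a functional assay on cells (Homo sapiens) for cytotoxicity (on this read-out lower numbers stand for higher toxicity in this test and higher numbers for lower toxicity in this test), compound 1 gives > 25000 nM, which is a limit of the assay and not a number.
Compound 2 `O=C1N(CCCCCCCOc2ccc(Cl)cc2)CCN1c1ccncc1` — in this assay compound 2 gives > 25000 nM, again a limit.
Compound 3 `O=C1N(CCCCCCOc2ccc(Cl)cc2)CCN1c1cccnc1` — in this assay compound 3 gives > 25000 nM, also a limit.

Compound 3 therefore stands where every measured compound stands: at the limit of > 25000 nM in this assay, at which 3 of the 3 values shown sit, with no number to set it apart from compound 1 or compound 2. The unmeasured compound 4 `O=C1N(CCCCCCCOc2ccc(Cl)cc2)CCN1c1cccnc1` differs from it by (4-chlorophenoxy)methyl in place of 4-chlorophenoxy on a saturated chain carbon, six bonds along the chain from an amide-type nitrogen in a ring. The same chain change has been made once before, a step that the two limits leave unreadable from compound 1 to compound 2, and its size could not be read because both ends sit at the limit. The other measured step, a step that the two limits leave unreadable from compound 1 to compound 3, is equally unreadable. Nothing in these data suggests that compound 4 would leave the limit; it is expected to give 40000 nM in this assay, within a range of 20000 nM to 100000 nM. The step that this estimate implies, a step that the limit leaves unreadable from compound 3 to compound 4, is expected to stay within the scatter, most likely as a further limit rather than a number.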

Compound 4, half-maximal cytotoxic concentration: > 25000 nM
Compound 4: no number, only a limit (the forecaster's own chance of this, stated with the estimate: 85%); the middle value is on the limit's open side.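

The steps from compound 3 to compound 4 and from compound 2 to compound 4 cannot be read, because both ends of each step sit at a limit: the limit of > 25000 nM in this assay, at which 4 of the 4 values shown sit.

The compounds shown leave open whether either the chain change or the pyridine change alters the result in this assay at all.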